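Compound 2 to compound 4: from carbonyl to benzyl

A few compounds are considered here, and "the series" means these few. Any claim that something is new, unique, unknown or untested is made for them only; others in the source may bear on it.

Among the measured compounds shown here, in an ADME assay on cells (Hepatocyte, Homo sapiens) for metabolic stability, read by LC-MS, with a stated time of 3 h, tested at 1 uM (a lower number here means slower removal, a higher number faster removal of the compound), compound 2 `CS(=O)(=O)NC(=O)c1cc(C2CC2)c(OCC2CCN(C(=O)c3cc(Cl)cc(Cl)c3)CC2)cc1F` gives 7.5 mL/min/kg, the only clearance value that is a number. Compound 1 `CC(C)(c1cc(Cl)cc(Cl)c1)N1CCC(COc2cc(F)c(C(=O)NS(C)(=O)=O)cc2C2CC2)CC1` gives < 6.2 mL/min/kg, which is a limit. Compound 3 `CS(=O)(=O)NC(=O)c1cc(C2CC2)c(OCC2CCN(C(c3ccccc3)c3ccccc3)CC2)cc1F` gives < 6.2 mL/min/kg, also a limit.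

Compound 4 `CS(=O)(=O)NC(=O)c1cc(C2CC2)c(OCC2CCN(Cc3cc(Cl)cc(Cl)c3)CC2)cc1F` has 3,5-dichlorobenzyl in place of (3,5-dichlorophenyl)carbonyl on an amine nitrogen in a ring. For the measured compounds named here, the one measured step that bears on this change also involves that carbonyl group, and it is an at least 1.2-fold higher number from compound 1 to compound 2 (0.08 log units; that floor lies within the scatter). It gives only a floor on size and sets no firm direction, so no step beyond the scatter is expected. The expected step is a 1.1-fold lower number from compound 2 to compound 4 (0.03 log units; within the scatter). For compound 4 the estimated clearance is 7 mL/min/kg, with an expected range of 4 mL/min/kg to 13 mL/min/kg.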

Compound 4, clearance: 15 mL/min/kg
Compound 4: the middle estimate sits 2.1-fold (0.33 log units) below what was measured, outside the stated range (above it).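

Among the compounds shown here, on the amine nitrogen in the ring, 3,5-dichlorobenzyl gives the only step in this assay that is printed as beyond the scatter: an at least 2.4-fold higher number from compound 1 to compound 4 (0.38 log units; beyond the scatter). Against the carbonyl, the same group stays within the scatter, a 2.0-fold higher number from compound 2 to compound 4 (0.30 log units; within the scatter), so compound 2 and compound 4 are not separated. The value of compound 1 is a limit, so its step gives only a floor: the limit of < 6.2 mL/min/kg in this assay, at which 2 of the 4 values shown sit.

Open, going by these compounds, is where 1-(3,5-dichlorophenyl)ethyl, with its single methyl, would fall on this nitrogen. On these data alone, a true size for the step from the 1-methylethyl group also remains open.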